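Compound 4: a 4-cyanophenyl in Place of 2-methylphenyl

The source may hold more compounds than are shown below. What is called first, only, known or untested is meant among the compounds shown, and "the series" means these compounds.

Of the compounds shown here, three on one shared core have been measured in a functional assay (muscle tissue) with Cavia porcellus as the target; a lower number here means that less compound is needed, a higher number that more compound is needed for the effect. Compound 1 `COC(=O)C1=C(C)N=C(C)/C(=C(\O)OC)C1c1ccccc1C#N` gives 15.9 nM, compound 2 `COC(=O)C1=C(C)N=C(C)/C(=C(\O)OC)C1c1ccc(F)cc1` gives 129 nM, and compound 3 `COC(=O)C1=C(C)N=C(C)/C(=C(\O)OC)C1c1ccccc1C` gives 6.03 nM. Compound 3 stands lowest of the three: the nearest step is a 2.6-fold lower number from compound 1 to compound 3 (0.42 log units; beyond the scatter) and the furthest is a 21-fold lower number from compound 2 to compound 3 (1.33 log units; beyond the scatter), both beyond the scatter.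

Compound 4 `COC(=O)C1=C(C)N=C(C)/C(=C(\O)OC)C1c1ccc(C#N)cc1` differs from compound 3 in one place. 4-cyanophenyl in place of 2-methylphenyl on a saturated ring carbon

For the measured compounds named here, two measured steps bear on this change. The exchange of cyano for methyl on the same aromatic carbon is seen in a 2.6-fold lower number from compound 1 to compound 3 (0.42 log units; beyond the scatter), a modest shift. The move from a 2-substituted to a 4-substituted phenyl is seen in an 8.1-fold higher number from compound 1 to compound 2 (0.91 log units; beyond the scatter) and in a 21-fold lower number from compound 2 to compound 3 (1.33 log units; beyond the scatter), both larger and both in the direction of a higher number. Compound 4 combines a cyano with the 4-substitution pattern of compound 2, so the writer expects a clear rise, estimated as a 17-fold higher number from compound 3 to compound 4 (1.22 log units; beyond the scatter). For compound 4 in this assay the estimate is 100 nM, with a range from 25 nM to 400 nM.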

Compound 4, half-maximal effective concentration: 3470 nM
For compound 4 the middle estimate is 35-fold (1.54 log units) below the measured one; the measured number lies above the stated range.
By their numbers in this assay, from the lowest: compound 3; then compound 1; then compound 2; then compound 4.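

In this assay, the same nitrile gives very different numbers depending on where it sits on the phenyl ring, with a 220-fold higher number from compound 1 to compound 4 (2.34 log units; beyond the scatter), so 4-cyanophenyl and 2-cyanophenyl are far from interchangeable at this position. The 4-substituted compounds also differ widely from one another, with a 27-fold higher number from compound 2 to compound 4 (1.43 log units; beyond the scatter), and a 580-fold higher number from compound 3 to compound 4 (2.76 log units; beyond the scatter) makes the swap of 2-methylphenyl for 4-cyanophenyl the widest step in the set, leaving compound 4 with the highest number of the four. No accompanying measurement accounts for the size of these steps.

For the compounds shown here, the nitrile is the only group seen in both the 2- and the 4-substituted form, so it stays open whether a phenyl carrying a methoxy group or an amine would show a similar gap. Going by these compounds, whether any 4-substituted phenyl can reach the low numbers of compound 1 and compound 3 also stays open.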